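The source may hold more compounds than are shown below. What is called first, only, known or untested is meant among the compounds shown, and "the series" means these compounds.

In an assay on isolated protein for inhibition of phosphodiesterase 4A (Sus scrofa) (a higher number here means a weaker inhibitor, a lower number a stronger inhibitor), the three measured compounds give these numbers:

Compound 1 `COc1ccc(C(=O)Nc2ccccc2C)cc1OC1CCCC1` gives 300 nM.
Compound 2 `COc1ccc(C(=O)Nc2ccccc2SC)cc1OC1CCCC1` gives 1200 nM.
Compound 3 `COc1ccc(C(=O)Nc2ccncc2Cl)cc1OC1CCCC1` gives 16 nM.

Compound 3 therefore stands lowest of the three, meaning it is the strongest inhibitor; its nearest neighbour is reached by a 19-fold lower number from compound 1 to compound 3 (1.27 log units; beyond the scatter) and its furthest by a 75-fold lower number from compound 2 to compound 3 (1.88 log units; beyond the scatter). Compound 4 `COc1ccc(C(=O)Nc2c(C)nsc2Br)cc1OC1CCCC1` is not yet measured. It differs from compound 3 in one place: 5-bromo-3-methyl-1,2-thiazol-4-yl in place of 3-chloropyridin-4-yl on an amide-type nitrogen. The two steps that bear on this are the ones that swapped the group on the amide-type nitrogen, a 19-fold lower number from compound 1 to compound 3 (1.27 log units; beyond the scatter) and a 75-fold lower number from compound 2 to compound 3 (1.88 log units; beyond the scatter), both large, while the change within one such group, a 4.0-fold higher number from compound 1 to compound 2 (0.60 log units; beyond the scatter), was modest. Among the measured compounds shown here, both large steps ran towards the 3-chloropyridin-4-yl group that now leaves, and no measured pair shows a five-membered ring in this place, so the direction is uncertain and a step away from the lowest number seems the more likely. Compound 4 is expected to give 50 nM, within 10 nM to 250 nM, which means an estimated 3.1-fold higher number from compound 3 to compound 4 (0.49 log units; beyond the scatter).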

Compound 4, half-maximal inhibitory concentration: 500 nM
The estimate for compound 4 lay 10-fold (1.00 log units) below the measured number; measured number outside the range, above it.
By their numbers in this assay, from the lowest: compound 3; then compounds 1 and 4 (each within the scatter of the next); then compound 2.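

On the amide-type nitrogen, 5-bromo-3-methyl-1,2-thiazol-4-yl does not keep the low number of 3-chloropyridin-4-yl, even though both groups have 7 heavy atoms and both carry a halogen (a 31-fold higher number from compound 3 to compound 4 (1.49 log units; beyond the scatter)). A halogen-bearing aromatic ring of this size is therefore not enough on its own to match compound 3. The new group also cannot be told apart from the 2-methylphenyl group of compound 1 (a 1.7-fold higher number from compound 1 to compound 4 (0.22 log units; within the scatter)), while it gives a modestly lower number than the 2-(methylsulfanyl)phenyl group of compound 2 (a 2.4-fold lower number from compound 2 to compound 4 (0.38 log units; beyond the scatter)), so compound 3 alone stands well apart.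

Still open, going by these compounds, is whether the ring nitrogen or the chlorine of 3-chloropyridin-4-yl matters more, a question that a 2-chlorophenyl group and an unsubstituted pyridin-4-yl group could separate. Nothing available here gives a reason for the size of these steps.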